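Cytotoxicity notes on the cyclic sulfonylurea series

A few compounds are considered here, and "the series" means these few. Any claim that something is new, unique, unknown or untested is made for them only; others in the source may bear on it.

Compound 1 `O=C1c2ccccc2NS(=O)(=O)N1COCCO` carries a 2-hydroxyethoxy group; in a functional assay on HEL cells (Homo sapiens) for cytotoxicity (a lower number here means that less compound is tolerated, a higher number that more compound is tolerated), compound 1 gives > 50 ug/mL, which is a limit of the assay and not a number. Within the data shown here, compound 2 `O=C1c2ccccc2NS(=O)(=O)N1Cc1ccccc1` gives 50 ug/mL in this assay; this is the only number. The step of a number no higher from compound 1 to compound 2 (the limit leaves the size open) cannot be sized because one end sits at the limit of > 50 ug/mL in this assay, at which 1 of the 2 values shown sits. The unmeasured compound 3 `CC(=O)OCCOCN1C(=O)c2ccccc2NS1(=O)=O` differs from compound 2 by 2-acetoxyethoxy in place of phenyl on a saturated chain carbon bound to an amide-type nitrogen in a ring. Among the measured compounds shown here, no measured step bears on this change with a readable size, so no step beyond the scatter is expected, and an expected step of no change at the digits printed from compound 2 to compound 3 (within the scatter) is taken. Compound 3 is therefore estimated at 50 ug/mL in this assay, with a range from 25 ug/mL to 100 ug/mL, and the value may again be reported only as a limit.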

Compound 3, minimum cytotoxic concentration: > 50 ug/mL
Compound 3 was reported as a limit (the forecaster's own chance of this, stated with the estimate: 50%); the middle value sits exactly at the limit.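

In this assay compound 3 gives > 50 ug/mL, which is a limit of the assay and not a number. On a saturated chain carbon bound to an amide-type nitrogen in a ring, 2-acetoxyethoxy in place of phenyl gives a number no lower from compound 2 to compound 3 (the limit leaves the size open), so the direction is now seen with phenyl as the starting group, and not only with phenyl as the entering group. Acetyl in place of hydrogen on an oxygen on a saturated carbon leaves compound 1 and compound 3 both reported as limits, and none of the new steps can be sized: the limit of > 50 ug/mL in this assay, at which 2 of the 3 values shown sit.

Going by these compounds, only compound 2 gives a number, 50 ug/mL, so how far the two oxygen-bearing chains lie from it remains open. On these data alone, what an amine, a carboxylic acid or a longer chain at this place would give in this assay also remains open.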